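Compound 3 to compound 4: aminomethyl for 4-methylpiperazin-1-yl

The compounds below may be only part of what the source reports. "The series", "measured", "known", "first", "only" and "open" are said of these compounds alone.

In an ADME assay on CHO cells (Cricetulus griseus) for cytotoxicity, read by MTT assay (a higher number here means that more compound is tolerated, a lower number that less compound is tolerated), compound 3 (`CN1CCN(C2CCN(c3nccc4[nH]c(-c5cccc(OC(F)(F)F)c5)nc34)CC2)CC1`) gives 3000 nM, and compound 1 (`CN1CCN(C2CCN(c3nccc4[nH]c(-c5ccc(F)c(F)c5)nc34)CC2)CC1`) gives 5000 nM. These two do not separate: a 1.7-fold lower number from compound 1 to compound 3 (0.22 log units; within the scatter), so the aryl change offers little guidance here. Compound 2 (`NC1CCN(c2nccc3[nH]c(-c4cccc(OC(F)(F)F)c4)nc23)CC1`) stands well clear of both at 42000 nM.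

Compound 4 (`NCC1CCN(c2nccc3[nH]c(-c4cccc(OC(F)(F)F)c4)nc23)CC1`) keeps the aryl group of compound 3 and has aminomethyl in place of 4-methylpiperazin-1-yl on a saturated ring carbon.

Going by the values given here, no measured compound carries aminomethyl. The closest evidence is the large step of a 14-fold lower number from compound 2 to compound 3 (1.15 log units; beyond the scatter), where 4-methylpiperazin-1-yl replaces amino on a saturated ring carbon. Removing 4-methylpiperazin-1-yl is therefore expected to raise the number in this assay beyond the scatter, though perhaps not all the way to the value of compound 2, since aminomethyl is not amino.

The expected change is a 7.3-fold higher number from compound 3 to compound 4 (0.87 log units; beyond the scatter). For compound 4 the estimated value is 22000 nM, with an expected range of 8000 nM to 60000 nM.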

Compound 4, half-maximal cytotoxic concentration: 2900 nM
Compound 4: the middle estimate sits 7.6-fold (0.88 log units) above what was measured; the measured number lies below the stated range.
By their numbers in this assay, from the lowest: compounds 4, 3 and 1 (each within the scatter of the next); then compound 2.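

In this assay the size of the group on this saturated ring carbon does not decide the outcome: 4-methylpiperazin-1-yl and aminomethyl do not separate (a 1.0-fold lower number from compound 3 to compound 4 (0.01 log units; within the scatter)), so losing the six-membered ring with 2 hetero atoms brings no gain on its own. The large shift lies instead between amino and aminomethyl (a 14-fold lower number from compound 2 to compound 4 (1.16 log units; beyond the scatter)), which leaves compound 2 alone at the high end, with compound 1, compound 3 and compound 4 together at the low end. Nothing measured here accounts for the gap between amino and aminomethyl.

On these data alone, whether the high number of compound 2 is particular to amino, or also holds for a hydroxyl or a carboxylic acid on the same ring carbon, stays open. Also open, as far as these compounds go, is where a longer chain such as 2-aminoethyl would fall.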